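A few compounds are considered here, and "the series" means these few. Any claim that something is new, unique, unknown or untested is made for them only; others in the source may bear on it.

In a functional assay (Homo sapiens) for inhibition, with a stated time of 72 h (a lower number here means a stronger inhibitor, a higher number a weaker inhibitor), compound 1 `COc1cc(C(=O)c2ccc3[nH]ccc3c2)cc(OC)c1OC` gives 111 nM, compound 2 `COc1cc(C(=O)c2ccc3c(ccn3C)c2)cc(OC)c1OC` gives 12.5 nM, and compound 3 `COc1cc(C(=O)c2ccc3c(ccn3C(C)C)c2)cc(OC)c1OC` gives 1600 nM, making compound 3 the weakest inhibitor of the three. Compound 4 `COc1cc(C(=O)c2ccc3c(ccn3CO)c2)cc(OC)c1OC` has hydroxymethyl in place of isopropyl on an aromatic nitrogen. Three measured steps change the group at this nitrogen. Two large steps lead up to the isopropyl compound: a 14-fold higher number from compound 1 to compound 3 (1.16 log units; beyond the scatter) and a 130-fold higher number from compound 2 to compound 3 (2.11 log units; beyond the scatter). The third, an 8.9-fold lower number from compound 1 to compound 2 (0.95 log units; beyond the scatter), is modest and goes down. Going by the values given here, no measured compound carries hydroxymethyl, so the size of the change remains uncertain. A large move to a lower number in this assay is nevertheless expected, with an estimated 27-fold lower number from compound 3 to compound 4 (1.43 log units; beyond the scatter). The estimate for compound 4 is 60 nM, with an expected range of 12 nM to 400 nM.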

Compound 4, half-maximal inhibitory concentration: 35 nM
Beside the measured number, compound 4's estimate is 1.7-fold (0.23 log units) above it, within the range that was stated.
By their numbers in this assay, from the lowest: compound 2; then compound 4; then compound 1; then compound 3.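

Hydroxymethyl on this aromatic nitrogen gives a far stronger inhibitor than isopropyl (a 46-fold lower number from compound 3 to compound 4 (1.66 log units; beyond the scatter)), so a group here does not have to weaken inhibition the way isopropyl does. Placing a hydroxy on the methyl group costs only a modest amount (a 2.8-fold higher number from compound 2 to compound 4 (0.45 log units; beyond the scatter)), and the result still beats the compound with hydrogen on this nitrogen (a 3.2-fold lower number from compound 1 to compound 4 (0.50 log units; beyond the scatter)). The gain over hydrogen is therefore not unique to methyl. Nothing given explains this order of the groups. On these data alone, whether an ethyl, methoxymethyl or aminomethyl group would sit nearer methyl or isopropyl remains open.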